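Swapping the aryl group on the triazole nitrogen of compound 3

The source may hold more compounds than are shown below. What is called first, only, known or untested is meant among the compounds shown, and "the series" means these compounds.

Of the compounds shown here, three of a shared spirocyclic core have been tested in a functional assay on HCT-116 cells (Homo sapiens) for antiproliferative activity, read by MTT assay, with a stated time of 48 h; on this read-out lower numbers stand for stronger inhibition and higher numbers for weaker inhibition. Compound 1 `N#CC1=C(N)Oc2c(c3nc4ccccc4nc3c3ccccc23)C12C(=O)N(Cc1cnnn1-c1cccc(Cl)c1)c1ccccc12` reached only the assay limit, and in this assay compound 1 gives > 50000 nM, which is a limit rather than a number. Compound 2 `Cc1ccc(-n2nncc2CN2C(=O)C3(C(C#N)=C(N)Oc4c3c3nc5ccccc5nc3c3ccccc43)c3ccccc32)c(C)c1` likewise stopped at the limit, and in this assay compound 2 gives > 50000 nM, again a limit. The change between them, a step that the two limits leave unreadable from compound 1 to compound 2, is therefore unreadable. Within the data shown here, compound 3 `N#CC1=C(N)Oc2c(N)cc3nc4ccccc4nc3c2C12C(=O)N(Cc1cnnn1-c1cccc(C(F)(F)F)c1)c1ccccc12` is the only one with a number: in this assay compound 3 gives 18900 nM, which is weak inhibition. Compound 3 stands alone against the other two values, as the limit of > 50000 nM in this assay, at which 2 of the 3 values shown sit, shows.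

Compound 4 `N#CC1=C(N)Oc2c(N)cc3nc4ccccc4nc3c2C12C(=O)N(Cc1cnnn1-c1c(F)cccc1F)c1ccccc12` differs from compound 3 at the aryl group on the aromatic nitrogen of the triazole ring: 2,6-difluorophenyl in place of 3-(trifluoromethyl)phenyl on an aromatic nitrogen. Among the measured compounds shown here, the single measured step at this same position, from compound 1 to compound 2, cannot be sized, so no step at this position gives a readable size or direction. The expectation is therefore a step of a 1.3-fold higher number from compound 3 to compound 4 (0.12 log units; within the scatter), that is, no change beyond the scatter. Compound 4 is estimated to give 25000 nM in this assay, within a range from 8000 nM to 80000 nM, with a fair chance of only a limit being reported.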

Compound 4, half-maximal inhibitory concentration: > 50000 nM
Compound 4: a limit, no number; the forecaster's own chance of this, stated with the estimate: 40%; at least 2.0-fold (0.30 log units) between middle value and limit.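

Among these compounds, this is the first step at the aryl group on the triazole nitrogen whose direction can be read: in this assay, replacing 3-(trifluoromethyl)phenyl with 2,6-difluorophenyl gives an at least 2.6-fold higher number from compound 3 to compound 4 (0.42 log units; beyond the scatter). The choice of aryl group at this position therefore matters to the read-out, and the change goes toward weaker inhibition. The step has a minimum size but no known maximum, because compound 4 reaches only a limit, as most of the set does: the limit of > 50000 nM in this assay, at which 3 of the 4 values shown sit.

On these data alone, the swap removes the trifluoromethyl group and adds two fluorines at once, so the step cannot be assigned to either part of the change alone, and it remains open whether any group here can improve on compound 3, which gives 18900 nM. Also open, as far as these compounds go, is how a plain phenyl, a pyridine ring or a saturated ring such as cyclohexyl would behave on the same triazole nitrogen, with the rest of compound 3 kept unchanged.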